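Thioether side-chain variation on the shared core

A few compounds are considered here, and "the series" means these few. Any claim that something is new, unique, unknown or untested is made for them only; others in the source may bear on it.

Measured so far in a functional assay on HT cells (Homo sapiens) for antiproliferative activity, read by fluorescence, with a stated time of 72 h; on this read-out higher numbers stand for weaker inhibition of growth and lower numbers for stronger inhibition of growth:
compound 1 `CC(C)c1n[nH]c2c(NCc3ccc(-c4ccccn4)cc3)nc(SCC3CNC(=O)O3)nc12`, 80 nM
compound 2 `CC(C)c1n[nH]c2c(NCc3ccc(-c4ccccn4)cc3)nc(SCCC(N)=O)nc12`, 120 nM

Among the compounds with values here, compound 2 gives the higher of the two numbers, nearest compound 1; the step of a 1.5-fold higher number from compound 1 to compound 2 (0.18 log units; within the scatter) is the only measured step, and it exchanges the group on the sulfur. Compound 3 `CC(C)c1n[nH]c2c(NCc3ccc(-c4ccccn4)cc3)nc(SC3CCCCC3N)nc12` differs from compound 2 in the same place: 2-aminocyclohexyl in place of 2-carbamoylethyl on a sulfur. Within the data shown here, the one relevant step, from compound 1 to compound 2, stayed within the scatter, so for compound 3 a step of no change at the digits printed from compound 2 to compound 3 (within the scatter) is expected, none beyond the scatter. Compound 3 is therefore estimated at 120 nM, between 40 nM and 360 nM.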

Compound 3, concentration for 50% growth inhibition: 139 nM
The estimate for compound 3 lay 1.2-fold (0.06 log units) below the measured number, within the range that was stated.
By their numbers in this assay, from the lowest: compounds 1, 2 and 3 (each within the scatter of the next).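

On the sulfur, the step of a 1.2-fold higher number from compound 2 to compound 3 (0.06 log units; within the scatter) in this assay replaces the open 2-carbamoylethyl chain with the ring of 2-aminocyclohexyl, and the step of a 1.7-fold higher number from compound 1 to compound 3 (0.24 log units; within the scatter) likewise compares that ring with (2-oxo-1,3-oxazolidin-5-yl)methyl. This position has therefore now carried a six-membered carbon ring with an amine as well as the two earlier groups, with no step beyond the scatter. No measurement shown offers an explanation for this result.

Going by these compounds, whether a carboxylic acid, a longer alkyl chain or a phenyl ring on the sulfur would give a step beyond the scatter remains open.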